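A few compounds are considered here, and "the series" means these few. Any claim that something is new, unique, unknown or untested is made for them only; others in the source may bear on it.

Compound 1 `CCCCCCCCS(=O)(=O)Nc1cc(-c2cccc(Cl)c2)ccc1C(=O)O`: 13800 nM
Compound 2 `CCCCCCCCS(=O)(=O)Nc1cc(-c2ccc(CCCC)cc2)ccc1C(=O)O`: 15700 nM
Compound 3 `CCCCCCCCS(=O)(=O)Nc1cc(-c2ccccc2F)ccc1C(=O)O`: 47200 nM

In an assay on mitochondria (strain BALB/c) for inhibition of glycerol-3-phosphate acyltransferase 1, mitochondrial (Mus musculus), read by scintillation counting, with a stated time of 10 min (on this read-out lower numbers stand for stronger inhibition and higher numbers for weaker inhibition), compound 3 gives the highest number of the three, set apart from compound 2 by a 3.0-fold higher number from compound 2 to compound 3 (0.48 log units; beyond the scatter) and from compound 1 by a 3.4-fold higher number from compound 1 to compound 3 (0.53 log units; beyond the scatter). Compound 4 `CCCCCCCCS(=O)(=O)Nc1cc(-c2cccc(F)c2)ccc1C(=O)O` has not yet been measured; it differs from compound 3 by 3-fluorophenyl in place of 2-fluorophenyl on an aromatic carbon. The step from compound 1 to compound 3 bears most directly on this change, since compound 1 carries 3-chlorophenyl, the nearest measured relative of the incoming 3-fluorophenyl, and that step was modest but beyond the scatter. A step of similar size in the opposite direction is therefore expected. Compound 4 is expected to give 16000 nM in this assay, within 6000 nM to 42000 nM. That expectation corresponds to a 3.0-fold lower number from compound 3 to compound 4 (0.47 log units; beyond the scatter).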

Compound 4, half-maximal inhibitory concentration: 32600 nM
Compound 4: middle estimate off by 2.0-fold (0.31 log units), on the low side; low and high end bracket the measured number.
By their numbers in this assay, from the lowest: compounds 1 and 2 (each within the scatter of the next); then compounds 4 and 3 (each within the scatter of the next).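

In this assay, 3-fluorophenyl in place of 2-fluorophenyl gives a 1.4-fold lower number from compound 3 to compound 4 (0.16 log units; within the scatter) and so does not separate these two fluorophenyl groups on this aromatic carbon. With the group held at the same ring place, swapping the halogen does separate the compounds: fluoro in place of chloro gives a 2.4-fold higher number from compound 1 to compound 4 (0.37 log units; beyond the scatter) and 3-fluorophenyl in place of 4-butylphenyl gives a 2.1-fold higher number from compound 2 to compound 4 (0.32 log units; beyond the scatter) as well. Nothing available here explains these steps. Open, from the compounds shown here alone, is how 4-fluorophenyl would compare with these two fluorophenyl groups. Also open, going by these compounds, is whether 3-bromophenyl or 3-methoxyphenyl would follow 3-chlorophenyl or 3-fluorophenyl.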